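Thiosemicarbazones on a shared core: heteroaryl swap at the imine carbon

The source may hold more compounds than are shown below. What is called first, only, known or untested is meant among the compounds shown, and "the series" means these compounds.

Measured so far:
compound 1 `CC1=CC[C@H](C(C)(C)NC(=S)N/N=C/c2cccc(Cl)c2)CC1` gives 35800 nM
compound 2 `CC1=CC[C@H](C(C)(C)NC(=S)N/N=C/c2ccco2)CC1` gives 81500 nM

Compound 2 holds the highest number of the two in a functional assay on U-251 cells (Homo sapiens) for inhibition, read by sulforhodamine B assay, with a stated time of 48 h; a lower number here means a stronger inhibitor of growth, a higher number a weaker inhibitor of growth; its nearest neighbour is compound 1, and the step of a 2.3-fold higher number from compound 1 to compound 2 (0.36 log units; beyond the scatter) is modest but beyond the scatter.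

Compound 3 `CC1=CC[C@H](C(C)(C)NC(=S)N/N=C/c2cccs2)CC1` is not yet measured in this assay. It differs from compound 2 by thiophen-2-yl in place of furan-2-yl on a carbon with a double bond to nitrogen. Among the measured compounds shown here, the only measured step, from compound 1 to compound 2, exchanges a six-membered ring for a five-membered one and so bears on this change only loosely; no measured pair exchanges one five-membered heteroaryl for another. Given that thiophen-2-yl stands between the two measured groups in size and ring type, the number for compound 3 is expected to sit near that of compound 2 or somewhat lower, a 1.5-fold lower number from compound 2 to compound 3 (0.17 log units; within the scatter), without confidence that it clears the scatter. The estimate for compound 3 is 55000 nM, within 25000 nM to 120000 nM.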

Compound 3, concentration for total growth inhibition: 27400 nM
Compound 3: middle estimate off by 2.0-fold (0.30 log units), on the high side; the range from low to high includes it.
By their numbers in this assay, from the lowest: compounds 3 and 1 (each within the scatter of the next); then compound 2.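

In this assay, among the compounds shown here, replacing furan-2-yl with thiophen-2-yl on a carbon with a double bond to nitrogen gives a 3.0-fold lower number from compound 2 to compound 3 (0.47 log units; beyond the scatter) and is the first measured exchange of one five-membered heteroaryl for another. The two groups have the same ring size and heavy-atom count and differ in the ring hetero atom, oxygen or sulfur, so a five-membered ring at this place does not by itself set the number. The step of a 1.3-fold lower number from compound 1 to compound 3 (0.12 log units; within the scatter) leaves thiophen-2-yl and 3-chlorophenyl unseparated, and the data offer no measured basis for explaining the difference between furan-2-yl and thiophen-2-yl.

As far as these compounds go, whether a pyridin-2-yl group would track with 3-chlorophenyl and thiophen-2-yl or with furan-2-yl remains open. Also open, from the compounds shown here alone, is how an amine or a carboxylic acid on the aryl ring would affect the number.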